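The compounds below may be only part of what the source reports. "The series", "measured", "known", "first", "only" and "open" are said of these compounds alone.

Measured so far in an ADME assay on MCF7 cells (Homo sapiens) for cytotoxicity, with a stated time of 72 h; a lower number here means a stronger inhibitor, a higher number a weaker inhibitor:
compound 1 `Oc1ccccc1CNc1ncnc2c1ncn2C1CCCCO1`: > 100000 nM (a limit)
compound 2 `COc1cccc(CNc2ncnc3c2ncn3C2CCCCO2)c1`: 97000 nM
compound 3 `COc1ccc(CNc2ncnc3c2ncn3C2CCCCO2)cc1`: > 100000 nM (a limit)

Within the data shown here, compound 2 gives the only actual number in the set, 97000 nM. For compound 1 and compound 3 the reading is the limit of > 100000 nM in this assay, at which 2 of the 3 values shown sit.

Compound 4 `COc1cccc(CNc2ncnc3c2ncn3C2CCCCO2)c1O` keeps all of compound 2 and changes it in one place: hydroxy in place of hydrogen on an aromatic carbon. The new hydroxy stands on an aromatic carbon, ortho to a large group and ortho to a methoxy group.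

Among the measured compounds shown here, no measured step matches this change exactly. For the measured compounds named here, the nearest precedent is compound 1, which also carries a hydroxy on that aromatic ring, and the step there is an at least 1.0-fold lower number from compound 1 to compound 2 (0.01 log units; that floor lies within the scatter). The other two steps add little: an at least 1.0-fold higher number from compound 2 to compound 3 (0.01 log units; that floor lies within the scatter) and a step that the two limits leave unreadable from compound 1 to compound 3. None of the three shows a movement beyond the scatter, so no step beyond the scatter is expected in this assay for the added hydroxy.

The estimated step is a 1.1-fold lower number from compound 2 to compound 4 (0.03 log units; within the scatter).

Compound 4 is expected at 90000 nM, with an estimated range of 40000 nM to 150000 nM.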

Compound 4, half-maximal inhibitory concentration: > 100000 nM
Compound 4: only a limit was reported (the forecaster's own chance of this, stated with the estimate: 60%); at least 1.1-fold (0.04 log units) between middle value and limit.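

Compound 4 puts a hydroxy on the aromatic carbon ortho to a large group and ortho to a methoxy group, and its reading in this assay is a limit, not a number: the limit of > 100000 nM in this assay, at which 3 of the 4 values shown sit.

Set against compound 2, the added hydroxy gives an at least 1.0-fold higher number from compound 2 to compound 4 (0.01 log units; that floor lies within the scatter), so this position shows no readable movement in this assay for this change. Compound 4 is also the first in the series to carry hydroxy and methoxy on the same ring, and the pairing gives no actual number in this assay's range; the steps joining compound 1 to the other limit readings cannot be read.

Among these compounds, with compound 2 as the only actual number, the series gives no ranking, and how far compound 1, compound 3 and compound 4 lie past their limits stays open. Going by these compounds, it also remains open whether an amine, a carboxylic acid or a longer chain on this ring would give a reading clearly separated from compound 2 in this assay.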